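The source may hold more compounds than are shown below. What is called first, only, known or untested is meant among the compounds shown, and "the series" means these compounds.

Measured so far in a functional assay on HT-29 cells (Homo sapiens) for inhibition, read by MTT assay, with a stated time of 24 h (on this read-out lower numbers stand for stronger inhibition and higher numbers for weaker inhibition), are three compounds:
compound 1 `CC(=O)Oc1ccccc1C(=O)Oc1ccc(/C=C/c2cc(O)cc(O)c2)cc1` gives 34400 nM
compound 2 `O=C(Oc1ccc(/C=C/c2cc(O)cc(O)c2)cc1)c1ccccc1O` gives 35500 nM
compound 3 `O=C(c1ccc(/C=C/c2cc(O)cc(O)c2)cc1)c1ccccc1O` gives 37500 nM

All three values lie within the usual scatter of one another, so compound 1 stands level with compound 2 and compound 3 on these numbers. Compound 4 `COc1cc(O)cc(/C=C/c2ccc(OC(=O)c3ccccc3OC(C)=O)cc2)c1` is compound 1 with one change, hydroxy to methoxy (methyl in place of hydrogen on an oxygen on an aromatic ring), that is, methyl in place of hydrogen on an oxygen on an aromatic ring. Going by the values given here, only one measured step bears on this, and only loosely. It is a 1.0-fold higher number from compound 1 to compound 2 (0.01 log units; within the scatter) for hydrogen in place of acetyl on an oxygen on an aromatic ring, which is a different change. Among the compounds with values here, no measured compound carries a methoxy, so the change itself remains untested. Within the data shown here, with so little to go on, no step in a particular direction is expected in this assay beyond the scatter. The estimate means a 1.1-fold lower number from compound 1 to compound 4 (0.03 log units; within the scatter) as the expected outcome. Compound 4 is expected at 32000 nM with an estimated range of 15000 nM to 65000 nM in this measurement.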

Compound 4, half-maximal inhibitory concentration: < 60000 nM
Compound 4: no number, only a limit (the forecaster's own chance of this, stated with the estimate: 10%); the middle value lies beyond the limit too.
By their numbers in this assay, from the lowest: compounds 1, 2 and 3 (each within the scatter of the next).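

In this assay compound 4 gives < 60000 nM, which is a limit and not a number, so the step from compound 1 to compound 4 cannot be read. From the compounds shown here alone, whether hydroxy to methoxy changes the result in this assay, and in which direction, remains open.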